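This account rests on a few compounds, and the source may have more. Where it says the series, first, only, none or still open, it means among the compounds named here.

Working notes on the phenylsulfonyl-free reading of the series are not possible here: every measured member shares one core and sits at the same ceiling. Compound 1 `O=C(O)CCC(=O)OCCOc1no[n+]([O-])c1S(=O)(=O)c1ccccc1` gives > 10000 nM in a functional assay on HT-29 cells (Homo sapiens) for antiproliferative activity, read by MTT assay, with a stated time of 72 h (a higher number here means a weaker inhibitor, a lower number a stronger inhibitor), and this is a limit, not a number. Compound 2 `O=C(O)CCCC(=O)OCCOc1no[n+]([O-])c1S(=O)(=O)c1ccccc1` gives > 10000 nM in this assay and this too is a limit. Compound 3 `O=C(O)CCCC(=O)OCCCOc1no[n+]([O-])c1S(=O)(=O)c1ccccc1` gives > 10000 nM in this assay and this is again a limit. Among the compounds with values here, the series so far therefore stands at the limit of > 10000 nM in this assay, at which 3 of the 3 values shown sit, and no order can be drawn within it.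

The next member is compound 4 `O=C(O)c1ccccc1C(=O)OCCOc1no[n+]([O-])c1S(=O)(=O)c1ccccc1` with the core of compound 1 kept. The change is 2-carboxyphenyl in place of 2-carboxyethyl on a carbonyl carbon and in words it is 2-carboxyphenyl in place of 2-carboxyethyl on a carbonyl carbon. Within the data shown here, the only measured step that bears on this change is a step that the two limits leave unreadable from compound 1 to compound 2 and it sets no size to carry over. On that basis, in this assay no step beyond the scatter is expected in either direction. The expected step is a step that the limit leaves unreadable from compound 1 to compound 4 and it remains an estimate. For compound 4 the estimated value is 15000 nM with an expected range from 5000 nM to 50000 nM and a report as a limit is the likelier outcome.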

Compound 4, half-maximal inhibitory concentration: > 10000 nM
Compound 4 gave a limit, no number; the forecaster's own chance of this, stated with the estimate: 75%; the middle value lies beyond the limit too.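

In this assay compound 4 gives > 10000 nM, and this is a limit, not a number. No step can be read from compound 1 or compound 2 to compound 4, since each pair holds only limits: the limit of > 10000 nM in this assay, at which 4 of the 4 values shown sit.

The compounds shown leave open whether any of the four differs from another in this assay, and which change, if any, would give a readable value.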